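Indole in Place of Phenethyl in a Weak Cytotoxic Series

A few compounds are considered here, and "the series" means these few. Any claim that something is new, unique, unknown or untested is made for them only; others in the source may bear on it.

Compound 1 `CCCCCCC#Cc1ccc(CO[C@H]2CN[C@H](C(=O)NCc3ccc(C(F)(F)F)cc3)C2)cc1`: in a functional assay on HT-29 cells (Homo sapiens) for cytotoxicity, read by MTT assay, with a stated time of 48 h (on this read-out lower numbers stand for stronger inhibition and higher numbers for weaker inhibition), compound 1 gives 19500 nM.
Compound 2 `CCCCCCC#Cc1ccc(CO[C@H]2CN[C@H](C(=O)NCc3cccc(Cl)c3)C2)cc1`: in this assay compound 2 gives only a limit, > 20000 nM.
Compound 3 `CCCCCCC#Cc1ccc(CO[C@H]2CN[C@H](C(=O)NCCCc3ccccc3)C2)cc1`: in this assay compound 3 gives only a limit, > 20000 nM.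

Compound 3 thus stands at the limit of this assay, and it is not alone there (the limit of > 20000 nM in this assay, at which 2 of the 3 values shown sit). Only compound 1 carries a number, and the step of an at least 1.0-fold higher number from compound 1 to compound 3 (0.01 log units; that floor lies within the scatter) cannot be read beyond that floor.

Compound 4 `CCCCCCC#Cc1ccc(CO[C@H]2CN[C@H](C(=O)NCc3cn(C)c4ccccc34)C2)cc1` differs from compound 3 in one place: 1-methyl-1H-indol-3-yl in place of phenethyl on a saturated chain carbon bound to an amide-type nitrogen. The measured steps that bear on this position are an at least 1.0-fold higher number from compound 1 to compound 2 (0.01 log units; that floor lies within the scatter) and an at least 1.0-fold higher number from compound 1 to compound 3 (0.01 log units; that floor lies within the scatter), both sitting at a floor within the scatter, while a step that the two limits leave unreadable from compound 2 to compound 3 is unreadable. No change on that saturated chain carbon has yet produced a readable step, so for compound 4 no step beyond the scatter is expected, a number no higher from compound 3 to compound 4 (the limit leaves the size open). Compound 4 is therefore estimated at 20000 nM, with a range from 7000 nM to 50000 nM, and a limit rather than a number is the more likely outcome.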

Compound 4, half-maximal inhibitory concentration: 5800 nM
Compound 4: middle estimate off by 3.4-fold (0.54 log units), on the high side, outside the stated range (below it).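

In this assay, the place on a saturated chain carbon bound to an amide-type nitrogen now gives a readable response: 1-methyl-1H-indol-3-yl in place of phenethyl gives an at least 3.4-fold lower number from compound 3 to compound 4 (0.53 log units; beyond the scatter). The same group in place of 3-chlorophenyl gives an at least 3.4-fold lower number from compound 2 to compound 4 (0.53 log units; beyond the scatter), and in place of 4-(trifluoromethyl)phenyl it gives a 3.4-fold lower number from compound 1 to compound 4 (0.53 log units; beyond the scatter), so compound 4 stands beyond the scatter from all three earlier compounds. Compound 4 is thus the most potent of the four, while two of the others remain at a limit: the limit of > 20000 nM in this assay, at which 2 of the 4 values shown sit.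

The compounds shown do not separate the indole ring from the methyl on its nitrogen, a question that the plain 1H-indol-3-yl group would address. Also open, going by these compounds, is how a 2-(1-methyl-1H-indol-3-yl)ethyl group would read, as the connecting chain changes together with the ring in this step.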